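Hydroxy in place of methoxy on the core of compound 2

The compounds below may be only part of what the source reports. "The series", "measured", "known", "first", "only" and "open" are said of these compounds alone.

Compound 2 `COc1ccc(CNC(=O)/C=C/c2coc3cc(OC)ccc3c2=O)cc1` gives the lowest number of the three measured compounds in an ADME assay on HepG2 2.2.15 cells (Homo sapiens) for cytotoxicity, read by MTT assay, with stated times of 48 h and 9 days (on this read-out higher numbers stand for lower toxicity in this test and lower numbers for higher toxicity in this test), 43000 nM. Compound 1 `O=C(/C=C/c1coc2cc(O)ccc2c1=O)NCc1ccc(F)cc1` gives 357000 nM and compound 3 `CCOc1ccc(NC(=O)/C=C/c2coc3cc(OC)ccc3c2=O)cc1` gives 460000 nM; both gaps to compound 2 lie beyond the scatter. Among the measured compounds shown here, the only single-point step within the measured set is an 11-fold higher number from compound 2 to compound 3 (1.03 log units; beyond the scatter), a change on the amide-type nitrogen that leaves the aromatic oxygen untouched.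

Compound 4 `COc1ccc(CNC(=O)/C=C/c2coc3cc(O)ccc3c2=O)cc1` differs from compound 2 in one place: hydrogen in place of methyl on an oxygen on an aromatic ring. For the measured compounds named here, no measured step isolates this change. Going by the values given here, compound 1 carries the hydroxy group, yet it also differs from compound 2 on the amide-type nitrogen, so its two values show only that the hydroxy-bearing compound 1 gives the higher number. On this thin basis a rise of modest size is expected for compound 4 in this assay, with wide uncertainty. Compound 4 is accordingly estimated at 90000 nM, between 25000 nM and 350000 nM. The expected step is a 2.1-fold higher number from compound 2 to compound 4 (0.32 log units; beyond the scatter).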

Compound 4, half-maximal cytotoxic concentration: 718000 nM
The estimate for compound 4 lay 8.0-fold (0.90 log units) below the measured number, and the stated range ends below it.
By their numbers in this assay, from the lowest: compound 2; then compounds 1, 3 and 4 (each within the scatter of the next).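

Notes on the aromatic oxygen: in this assay, methoxy to hydroxy on the core now stands as a single change and gives a large step on its own (a 17-fold higher number from compound 2 to compound 4 (1.22 log units; beyond the scatter)), which the values for compound 1 and compound 2 could not separate from the change on the amide-type nitrogen. With the hydroxy group in place, methoxy in place of fluoro on an aromatic carbon stays within the scatter (a 2.0-fold higher number from compound 1 to compound 4 (0.30 log units; within the scatter)), so these two hydroxy compounds are not told apart. Nothing available bears on the cause of the large step.

Open, as far as these compounds go, is whether the same change carries over to the 4-ethoxyphenyl amide of compound 3. Also open, from the compounds shown here alone, is how an amine or a carboxylic acid in place of the hydroxy group would read in this assay.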